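Methylating the ring nitrogen of compound 2

The compounds below may be only part of what the source reports. "The series", "measured", "known", "first", "only" and "open" are said of these compounds alone.

Measured values in a functional assay on A2780 cells (Homo sapiens) for antiproliferative activity, read by MTT assay, with a stated time of 48 h (a higher number here means a weaker inhibitor, a lower number a stronger inhibitor), are these
Compound 1 `COc1cc(C(=O)/C=C/c2c[nH]c3ccccc23)cc([N+](=O)[O-])c1OC` gives 1280 nM
Compound 2 `COc1cc(C(=O)/C=C/c2c[nH]c3ccccc23)cc(SC)c1OC` gives 169 nM

Compound 2 holds the lower of the two numbers, and its gap to compound 1 lies beyond the scatter. The next structure, compound 3 `COc1cc(C(=O)/C=C/c2cn(C)c3ccccc23)cc(SC)c1OC`, carries a single change from compound 2: methyl in place of hydrogen on an aromatic nitrogen. Among the measured compounds shown here, only one measured step exists, a 7.6-fold lower number from compound 1 to compound 2 (0.88 log units; beyond the scatter), and it is modest. For the measured compounds named here, that step concerns methylsulfanyl in place of nitro on an aromatic carbon, so it bears only indirectly on this nitrogen, and no measured pair tests the new change. No step beyond the scatter is therefore expected in this assay, and no direction is favoured. The estimate means a 1.2-fold lower number from compound 2 to compound 3 (0.08 log units; within the scatter) as the expected step. For compound 3 the estimated value is 140 nM, with an expected range from 40 nM to 500 nM.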

Compound 3, half-maximal inhibitory concentration: 193 nM
Beside the measured number, compound 3's estimate is 1.4-fold (0.14 log units) below it; measured number inside the range.
By their numbers in this assay, from the lowest: compounds 2 and 3 (each within the scatter of the next); then compound 1.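

In this assay, methyl in place of hydrogen on the aromatic nitrogen gives a 1.1-fold higher number from compound 2 to compound 3 (0.06 log units; within the scatter), so the two compounds cannot be told apart. Among the compounds shown here, the earlier step concerned a group on an aromatic carbon, whereas this pair gives the first reading at the ring nitrogen. For this pair, the nitrogen can carry either hydrogen or methyl with no difference beyond the scatter in this assay.

Going by these compounds, whether this tolerance extends to an ethyl group, or to a longer chain ending in an amine or a carboxylic acid, remains open. On these data alone, it is also open whether methyl on this nitrogen would give a similar result with nitro in place of methylsulfanyl on the aromatic carbon. No available evidence bears on the reason for this result.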